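Swapping the Amide Substituent in Compound 1

The source may report more compounds than this note shows. Statements on the series, on what has been measured and on what is new or still open speak of the compounds shown alone.

Compound 1 `Cc1cc(C(=O)NN2CCOCC2)nn1Cc1cc(Cl)cc2cc(-c3ccccc3)oc12` was tested in an assay on CHO-K1 cells for displacement of a labelled ligand from prostaglandin E2 receptor EP1 subtype (Homo sapiens), read by scintillation counting, with a stated time of 45 min (a lower number here means a stronger inhibitor, a higher number a weaker inhibitor), where compound 1 gives 10 nM. Among the measured compounds shown here, of the two numbers measured so far, compound 1 has the higher one; its nearest neighbour is compound 2 `Cc1cc(C(N)=O)nn1Cc1cc(Cl)cc2cc(-c3ccccc3)oc12`, which in this assay gives 5.01 nM. For the measured compounds named here, the one measured step between these compounds, a 2.0-fold lower number from compound 1 to compound 2 (0.30 log units; within the scatter), replaces morpholin-4-yl with hydrogen on the amide-type nitrogen and stays within the scatter. Compound 3 `Cc1cc(C(=O)NC[C@H]2CCCO2)nn1Cc1cc(Cl)cc2cc(-c3ccccc3)oc12` alters the same position: (oxolan-2-yl)methyl in place of morpholin-4-yl on an amide-type nitrogen. Because a 2.0-fold lower number from compound 1 to compound 2 (0.30 log units; within the scatter) remained within the scatter, a change of similar size at this nitrogen is expected to give no step beyond the scatter, and the expected step is no change at the digits printed from compound 1 to compound 3 (within the scatter). Compound 3 is therefore estimated at 10 nM in this assay, with a range expected to run from 3 nM to 30 nM.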

Compound 3, half-maximal inhibitory concentration: 6.31 nM
Beside the measured number, compound 3's estimate is 1.6-fold (0.20 log units) above it; low and high end bracket the measured number.
By their numbers in this assay, from the lowest: compounds 2, 3 and 1 (each within the scatter of the next).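

With a 1.6-fold lower number from compound 1 to compound 3 (0.20 log units; within the scatter) and a 1.3-fold higher number from compound 2 to compound 3 (0.10 log units; within the scatter) in this assay as its two new steps, compound 3 adds a third substituent on the amide-type nitrogen that stays within the scatter of both earlier compounds. The comparison now extends to a group with a five-membered ring and a defined stereocentre, and hydrogen, morpholin-4-yl and (oxolan-2-yl)methyl cannot be told apart at this position in these three compounds. No supporting information explains how closely these numbers agree.

The compounds shown leave open whether the opposite stereoisomer of the (oxolan-2-yl)methyl group would also stay within the scatter. They also leave open whether a more different substituent on this nitrogen, such as a phenyl ring, an aminoethyl chain or a chain ending in a carboxylic acid, would give a step beyond it.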